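The compounds below may be only part of what the source reports. "The series", "measured", "known", "first", "only" and "open" are said of these compounds alone.

Working notes on the series in a functional assay on HCT-116 cells (Homo sapiens) for antiproliferative activity, read by MTT assay, with a stated time of 72 h; on this read-out higher numbers stand for weaker inhibition and lower numbers for stronger inhibition. Compound 1, `COc1ccc(/C=C2/CN(C)/C(=N/c3ccc(C)cc3)S2)cc1`, gives 11100 nM and has the lowest of the two numbers shown; compound 3, `COc1ccc(/C=C2\S/C(=N\c3ccc(F)cc3)N(C)C2=O)cc1`, is nearest with 13300 nM, and the gap between the two lies within the scatter, so no order between them is drawn. Compound 2, `COc1ccc(/C=C2\S/C(=N\c3ccccc3)N(C)C2=O)cc1`, sits only at the limit of the assay, > 100000 nM, which is the limit of > 100000 nM in this assay, at which 1 of the 3 values shown sits, and not a number. Going by the values given here, the single measured step with one end at that limit is an at least 7.5-fold lower number from compound 2 to compound 3 (0.87 log units; beyond the scatter).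

Compound 4, `COc1ccc(/C=C2/CN(C)/C(=N/c3ccc(C(F)(F)F)cc3)S2)cc1`, differs from compound 1 in one place: trifluoromethyl in place of methyl on an aromatic carbon. Among the compounds with values here, no measured step exchanges methyl for trifluoromethyl. Within the data shown here, the only measured change on an aromatic carbon of that ring, an at least 7.5-fold lower number from compound 2 to compound 3 (0.87 log units; beyond the scatter), stands on a different core and exchanges hydrogen for fluoro, so it bears on the present step only loosely. A step of a 1.5-fold lower number from compound 1 to compound 4 (0.17 log units; within the scatter) toward a somewhat lower number is expected in this assay, though not clearly beyond the scatter. Compound 4 is accordingly estimated at 7500 nM, from 2500 nM to 30000 nM.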

Compound 4, half-maximal inhibitory concentration: 34300 nM
Beside the measured number, compound 4's estimate is 4.6-fold (0.66 log units) below it; measured number above the stated range.
By their numbers in this assay, from the lowest: compounds 1 and 3 (each within the scatter of the next); then compound 4. At a limit, above all of these: compound 2.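

In this assay this position, para to a large group, proves sensitive on the core of compound 1: the exchange of methyl for trifluoromethyl gives a 3.1-fold higher number from compound 1 to compound 4 (0.49 log units; beyond the scatter) and so moves toward weaker inhibition. The earlier compounds shown here offered only an exchange of hydrogen for fluoro on a different core, which ran toward a lower number, so fluorine entering this ring does not lower the number in every case, and compound 4 goes against that single earlier direction. Nothing shown gives a measured cause for this step.

On these data alone, whether an amine, a hydroxyl or a carboxylic acid at this position would keep the number of compound 1 remains open. Also open, as far as these compounds go, is whether the same exchange of methyl for trifluoromethyl would run the same way on the core of compound 3.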